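The source may report more compounds than this note shows. Statements on the series, on what has been measured and on what is new or still open speak of the compounds shown alone.

Of the compounds shown here, three of one series have been tested in an ADME assay on NIH3T3 cells (Mus musculus) for cytotoxicity, read by MTT assay, with a stated time of 24 h; on this read-out higher numbers stand for weaker inhibition and lower numbers for stronger inhibition. Compound 1, `O=C(CN1CCN(c2ccccc2Cl)CC1)N1CCN(c2nnc(-c3ccccc3)c(-c3ccccc3)n2)CC1`, gives 350000 nM in this assay. Compound 2, `Cc1ccc(-c2nnc(N3CCN(C(=O)CN4CCN(c5ccccc5)CC4)CC3)nc2-c2ccc(C)cc2)cc1`, returns only a limit in this assay, > 914000 nM. Compound 3, `COc1ccc(-c2nnc(N3CCN(C(=O)CN4CCN(c5ccccc5)CC4)CC3)nc2-c2ccc(OC)cc2)cc1`, likewise returns only a limit in this assay, > 863000 nM. Compound 3 therefore stands not at a number but at a boundary of the assay, as the limit of > 863000 nM in this assay, at which 1 of the 3 values shown sits, records, and compound 2 sits at a boundary of the same kind, as the limit of > 914000 nM in this assay, at which 1 of the 3 values shown sits, records. No two of the measured compounds differ in just one place, so no single-point step can be read from them.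

Compound 4, `COc1ccc(-c2nnc(N3CCN(C(=O)CN4CCN(c5ccc([N+](=O)[O-])cc5)CC4)CC3)nc2-c2ccc(OC)cc2)cc1`, differs from compound 3 by one change: nitro in place of hydrogen on an aromatic carbon of a six-membered aromatic ring of carbon only, para to a large group. Because compound 3 gives only > 863000 nM, any movement in this assay can be seen only if it runs toward stronger inhibition. The step of an at least 1.2-fold lower number from compound 3 to compound 4 (0.09 log units; that floor lies within the scatter) is expected to stay within the scatter, with a fair chance of another limit. Compound 4 is expected to give about 700000 nM in this assay, within 250000 nM to 1500000 nM.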

Compound 4, half-maximal inhibitory concentration: > 801000 nM
Compound 4 gave a limit, no number (the forecaster's own chance of this, stated with the estimate: 60%); at least 1.1-fold (0.05 log units) between middle value and limit.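

In this assay compound 4 returns only a limit, > 801000 nM, and compound 3 also stands at a limit, so no step can be read between compound 3 and compound 4. The compounds shown leave open whether nitro in place of hydrogen on an aromatic carbon shifts this read-out at all, and in which direction.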